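From acetyl to difluoromethyl: an estimate without a baseline

The source may report more compounds than this note shows. Statements on the series, on what has been measured and on what is new or still open speak of the compounds shown alone.

Compound 1 `CC(=O)NCc1cccc(Cn2nc(NS(=O)(=O)c3ccc(Cl)s3)c3c(Cl)cccc32)c1` gives 6.03
Compound 2 `CC(=O)NCc1cccc(Cn2nc(NS(=O)(=O)c3ccc(Cl)s3)c3c(C#N)cccc32)c1` gives 5.4
Compound 3 `CC(=O)NCc1cccc(Cn2nc(NS(=O)(=O)c3ccc(Cl)s3)c3c(C(C)=O)cccc32)c1` gives "not determined" (no result reported)

These results come from a physicochemical assay for acid dissociation, and the three compounds differ in a single group on the shared core. Compound 3 has no number on this scale: its entry reads "not determined" (no result reported) and so it offers no starting point. Compound 4 `CC(=O)NCc1cccc(Cn2nc(NS(=O)(=O)c3ccc(Cl)s3)c3c(C(F)F)cccc32)c1` differs from it as follows: difluoromethyl in place of acetyl on an aromatic carbon with difluoromethyl in place of acetyl on an aromatic carbon. For the measured compounds named here, the one measured step at this same carbon is a number 0.63 log units lower from compound 1 to compound 2 (beyond the scatter) and it shows that in this assay a swap here can shift the number by a modest amount. No size or direction can be expected for the step from compound 3 itself, since that compound has no number. Difluoromethyl has not been measured on this core, so the expectation rests on the two known values and is a judgement: nearer compound 1 at 6.03 than compound 2 at 5.4 on this scale. Compound 4 is expected near 5.8 with an estimated range from 5.4 to 6.3 in this measurement.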

Compound 4, acid dissociation constant: 5.6
The estimate for compound 4 lay 0.20 log units above the measured number; low and high end bracket the measured number.
By their numbers in this assay, from the lowest: compounds 2 and 4 (each within the scatter of the next); then compound 1.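

In this assay the swap from chloro to difluoromethyl at this aromatic carbon gives a number 0.43 log units lower from compound 1 to compound 4 (beyond the scatter) and makes difluoromethyl the second group, after cyano, whose number stands clearly apart from that of chloro. Against cyano, the change gives a number 0.20 log units higher from compound 2 to compound 4 (within the scatter) and so leaves these two different groups unresolved on this scale. Steps from compound 3 cannot be read, and nothing available accounts for these shifts.

Still open, as far as these compounds go, is where other groups at this carbon would fall relative to chloro, cyano and difluoromethyl, for example an amine, a methoxy group or trifluoromethyl. Also open, from the compounds shown here alone, is whether these swaps would shift the number in the same way if another part of the shared core carried a different group.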